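The source may hold more compounds than are shown below. What is called first, only, known or untested is meant among the compounds shown, and "the series" means these compounds.

Values measured in a physicochemical assay for solubility, read by HPLC, in phosphate buffer, at pH 6.5; on this read-out lower numbers stand for lower solubility and higher numbers for higher solubility:
- Compound 1 `COC(=O)C1=C(C)NC(c2nccs2)=NC1(C)c1ccc(F)cc1`: 22 ug/mL
- Compound 2 `COC(=O)C1=C(CN2CCNCC2)NC(c2nccs2)=NC1(C)c1ccc(F)cc1`: 250 ug/mL
- Compound 3 `COC(=O)C1=C(CN2CCC(F)(F)CC2)NC(c2nccs2)=NC1(C)c1ccc(F)cc1`: < 1 ug/mL (a limit, not a number)

Compound 3 sits lowest of the three, and its entry is only a limit: the limit of < 1 ug/mL in this assay, at which 1 of the 3 values shown sits. Compound 4 `COC(=O)C1=C(Cn2ccnc2)NC(c2nccs2)=NC1(C)c1ccc(F)cc1` has not been measured yet. It carries 1H-imidazol-1-yl in place of 4,4-difluoropiperidin-1-yl on a saturated chain carbon bound to a double-bonded ring carbon.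

All three measured steps concern this same place, and all are large. Piperazin-1-yl gave an 11-fold higher number from compound 1 to compound 2 (1.06 log units; beyond the scatter), 4,4-difluoropiperidin-1-yl gave an at least 22-fold lower number from compound 1 to compound 3 (1.34 log units; beyond the scatter), and exchanging one group for the other gave an at least 250-fold lower number from compound 2 to compound 3 (2.39 log units; beyond the scatter). Compound 4 gives up the group behind an at least 22-fold lower number from compound 1 to compound 3 (1.34 log units; beyond the scatter), so its reading is expected to climb back towards compound 1 at 22 ug/mL. Within the data shown here, no measured compound carries 1H-imidazol-1-yl, so the range stays wide. A large upward step is expected in this assay, estimated as an at least 30-fold higher number from compound 3 to compound 4 (1.47 log units; beyond the scatter). For compound 4 the estimated value is 30 ug/mL, with an expected range of 6 ug/mL to 150 ug/mL.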

Compound 4, solubility: 338 ug/mL
Estimate against measurement, compound 4: 11-fold (1.05 log units) below; the whole stated range lies below it.
By their numbers in this assay, from the lowest: compound 1; then compounds 2 and 4 (each within the scatter of the next). At a limit, below all of these: compound 3.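

In this assay, 1H-imidazol-1-yl and piperazin-1-yl cannot be told apart at this place, with only a 1.4-fold higher number from compound 2 to compound 4 (0.13 log units; within the scatter), so a high reading here does not depend on piperazin-1-yl alone. Set against the plain hydrogen, 1H-imidazol-1-yl also gives a clear gain: a 15-fold higher number from compound 1 to compound 4 (1.19 log units; beyond the scatter). Exchanging 4,4-difluoropiperidin-1-yl for it gives an at least 330-fold higher number from compound 3 to compound 4 (2.52 log units; beyond the scatter), and that size is only a floor, since the starting entry is a limit: the limit of < 1 ug/mL in this assay, at which 1 of the 4 values shown sits.

The compounds shown do not tell which feature of the entering groups sets the reading. A plain piperidin-1-yl at this carbon would separate the part played by the two fluorines from that of the ring itself, and a morpholin-4-yl would add a further comparison with piperazin-1-yl.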